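A few compounds are considered here, and "the series" means these few. Any claim that something is new, unique, unknown or untested is made for them only; others in the source may bear on it.

Compound 1 `O=C(CCCCCCCOc1no[n+]([O-])c1S(=O)(=O)c1ccccc1)NO`: 630 nM
Compound 2 `O=C(COCCOc1no[n+]([O-])c1S(=O)(=O)c1ccccc1)NO`: 7400 nM

In a functional assay on KG-1 cells (Homo sapiens) for inhibition, read by MTT assay, with a stated time of 48 h (a higher number here means a weaker inhibitor, a lower number a stronger inhibitor), compound 2 has the higher of the two numbers. Going by the values given here, the only measured step is large: a 12-fold higher number from compound 1 to compound 2 (1.07 log units; beyond the scatter). That step changed the chain but kept the hydroxycarbamoyl group, so it offers only weak guidance here. Compound 3 `O=C(NO)OCCOCCOc1no[n+]([O-])c1S(=O)(=O)c1ccccc1` is not yet measured. Its change from compound 2 is ((hydroxycarbamoyl)oxy)methyl in place of hydroxycarbamoyl on a saturated chain carbon bound to an oxygen on a saturated carbon: ((hydroxycarbamoyl)oxy)methyl in place of hydroxycarbamoyl. Among the compounds with values here, no measured step shows this kind of replacement, so only a modest move within the wide uncertainty is expected: a 1.3-fold lower number from compound 2 to compound 3 (0.13 log units; within the scatter). The estimate for compound 3 is 5500 nM, with an expected range of 1500 nM to 20000 nM.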

Compound 3, half-maximal inhibitory concentration: 5380 nM
Estimate against measurement, compound 3: 1.0-fold (0.01 log units) above; the range from low to high includes it.
By their numbers in this assay, from the lowest: compound 1; then compounds 3 and 2 (each within the scatter of the next).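

In this assay the swap of hydroxycarbamoyl for ((hydroxycarbamoyl)oxy)methyl on this saturated chain carbon gives a 1.4-fold lower number from compound 2 to compound 3 (0.14 log units; within the scatter) and so cannot be told apart from repeat-measurement noise. The new ending also leaves compound 1 with the lowest number, as the comparison with 2-((hydroxycarbamoyl)oxy)ethoxy in place of 5-(hydroxycarbamoyl)pentyl shows (an 8.5-fold higher number from compound 1 to compound 3 (0.93 log units; beyond the scatter)). Nothing available explains either result. Still open, as far as these compounds go, is whether an all-carbon chain ending in the ((hydroxycarbamoyl)oxy) group would match compound 1, and whether a carboxylic acid could replace hydroxycarbamoyl.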